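A few compounds are considered here, and "the series" means these few. Any claim that something is new, unique, unknown or untested is made for them only; others in the source may bear on it.

Compound 1, `CCOC(=O)c1c(-c2cccc(OCc3ccccc3)c2)[nH]c2cc(OC)ccc2c1=O`: > 22000 nM
Compound 2, `CCOC(=O)c1c(-c2cccc(C(F)(F)F)c2)[nH]c2cc(OC)ccc2c1=O`: > 22000 nM

In an ADME assay on HEK293 cells (Homo sapiens) for cytotoxicity, read by luminescence, with a stated time of 72 h (a higher number here means that more compound is needed for the effect, a lower number that less compound is needed), compound 1 gives > 22000 nM, which is a limit of the assay and not a number. Compound 2 likewise gives > 22000 nM, again a limit. Going by the values given here, the step that the two limits leave unreadable from compound 1 to compound 2 is therefore unreadable, and the only thing the two measurements show together is the limit of > 22000 nM in this assay, at which 2 of the 2 values shown sit. Among the compounds with values here, compound 1 thus stands at the limit and nowhere more precisely; no measured compound here has a real number against it.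

Compound 3, `CCOC(=O)c1c(-c2cccc(CO)c2)[nH]c2cc(OC)ccc2c1=O`, is the compound not yet measured. It differs from compound 1 in one place: hydroxymethyl in place of benzyloxy on an aromatic carbon. Within the data shown here, no measured step bears on this particular change, and the one measured step available is itself unreadable, so there is nothing from which a size or a direction could be taken. The expectation for compound 3 in this assay is accordingly that it, too, lands at or past the limit, an estimated 30000 nM with a range from 15000 nM to 90000 nM, and an expected step that the limit leaves unreadable from compound 1 to compound 3, which is no step beyond the scatter.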

Compound 3, half-maximal effective concentration: > 22000 nM
Compound 3: only a limit was reported; the forecaster's own chance of this, stated with the estimate: 85%; the middle value does not contradict the limit.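

Going by these compounds alone, compound 3 ends at a limit and not a number, as do compound 1 and compound 2, so no step among the three can be read: the limit of > 22000 nM in this assay, at which 3 of the 3 values shown sit.

What the compounds shown leave open is where any of the three truly stands in this assay and whether benzyloxy, trifluoromethyl and hydroxymethyl differ there at all.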